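Ester series: oxazole in place of tolyl on the second acyl group

The source may hold more compounds than are shown below. What is called first, only, known or untested is meant among the compounds shown, and "the series" means these compounds.

The shared core of compound 1 `CC(=O)Oc1ccccc1C(=O)O[C@H]1CO[C@H]2[C@@H]1OC[C@H]2OC(=O)c1ccccc1C` carries two ester groups; the variations concern the acyl group on the second of them. In an ADME assay on a cell-free system (plasma, Homo sapiens) for metabolic stability, with Plasma (Rattus norvegicus) as the target, read by HPLC, at pH 7.4 (a higher number here means that the compound lasts longer, a lower number that the compound disappears faster), compound 1 gives 0.035 h. Compound 2 `CC(=O)Oc1ccccc1C(=O)O[C@H]1CO[C@H]2[C@@H]1OC[C@H]2OC(=O)c1cccc(C)c1` gives 0.165 h in this assay, and compound 3 `CC(=O)Oc1ccccc1C(=O)O[C@H]1CO[C@H]2[C@@H]1OC[C@H]2OC(=O)c1ccccc1OC(=O)c1ccccc1` gives 0.385 h. Compound 2 thus stands second highest of the three numbers, above compound 1 and below compound 3.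

Compound 4 `CC(=O)Oc1ccccc1C(=O)O[C@H]1CO[C@H]2[C@@H]1OC[C@H]2OC(=O)c1cnoc1C` differs from compound 2 in one place: 5-methyl-1,2-oxazol-4-yl in place of 3-methylphenyl on a carbonyl carbon. The two measured steps both alter the same acyl group and both raised the number: a 4.7-fold higher number from compound 1 to compound 2 (0.67 log units; beyond the scatter) and an 11-fold higher number from compound 1 to compound 3 (1.04 log units; beyond the scatter). Within the data shown here, neither step, however, exchanges the aromatic ring itself for a ring with hetero atoms, so no measured step bears directly on the present change.

For compound 4 a step of a 1.1-fold lower number from compound 2 to compound 4 (0.04 log units; within the scatter) is therefore expected in this assay, with a wide range in either direction. Compound 4 is estimated at 0.15 h, between 0.05 h and 0.5 h.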

Compound 4, half-life: 0.193 h
Estimate against measurement, compound 4: 1.3-fold (0.11 log units) below, within the range that was stated.
By their numbers in this assay, from the lowest: compound 1; then compounds 2, 4 and 3 (each within the scatter of the next, the first and the last beyond it).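

In this assay, replacing 3-methylphenyl on this carbonyl carbon with 5-methyl-1,2-oxazol-4-yl gives a 1.2-fold higher number from compound 2 to compound 4 (0.07 log units; within the scatter), so a five-membered aromatic ring with 2 hetero atoms can take the place of the six-membered carbon ring without a change beyond the scatter. The same group also stands well clear of 2-methylphenyl, with a 5.5-fold higher number from compound 1 to compound 4 (0.74 log units; beyond the scatter), which makes compound 1 the lowest of the four and shows that a ring of carbon only is not required at this place for a number above that of compound 1. The data offer no measured basis for explaining either step.

The compounds shown leave open whether the methyl on the 1,2-oxazole ring matters, as no compound here carries that ring without it. Going by these compounds, it also remains open how an acyl group without an aromatic ring, such as cyclohexylcarbonyl, or an aromatic acyl group bearing an amine or a carboxylic acid, would compare.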